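Estimating compound 3 from two measured analogues

This account rests on a few compounds, and the source may have more. Where it says the series, first, only, none or still open, it means among the compounds named here.

Measured compounds:
compound 1, `COc1ccc(-c2nc3cc(/C=C4\SC(=O)N(CC(=O)N5CCOCC5)C4=O)ccc3[nH]2)cc1OC`: 7510 nM
compound 2, `COc1ccc(-c2nc3cc(/C=C4\SC(=O)N(Cc5cc(OC)c(OC)c(OC)c5)C4=O)ccc3[nH]2)cc1OC`: 320 nM

Both compounds were tested in a functional assay on HeLa cells (Homo sapiens) for inhibition, read by MTT assay, with a stated time of 48 h; on this read-out higher numbers stand for weaker inhibition and lower numbers for stronger inhibition. Compound 2 stands lowest of the two numbers, since its nearest neighbour is compound 1, and the step of a 23-fold lower number from compound 1 to compound 2 (1.37 log units; beyond the scatter) lies beyond the scatter. That step exchanges the group on the chain carbon bound to the ring nitrogen at one end of the shared core.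

Compound 3, `COc1cc(-c2nc3cc(/C=C4\SC(=O)N(Cc5cc(OC)c(OC)c(OC)c5)C4=O)ccc3[nH]2)ccc1OCC(C)C`, has not been measured. It differs from compound 2 by isopropyl in place of hydrogen on a saturated chain carbon bound to an oxygen on an aromatic ring, at the opposite end of the molecule. Among the compounds with values here, no measured pair changes anything at that position, so the single known step gives no guidance here, and no step beyond the scatter is expected in this assay. Compound 3 is therefore expected to give about 400 nM, with a plausible range from 130 nM to 1500 nM. The implied step, a 1.3-fold higher number from compound 2 to compound 3 (0.10 log units; within the scatter), is expected to stay within the scatter.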

Compound 3, half-maximal inhibitory concentration: 250 nM
Compound 3: the middle estimate sits 1.6-fold (0.20 log units) above what was measured; the range from low to high includes it.
By their numbers in this assay, from the lowest: compounds 3 and 2 (each within the scatter of the next); then compound 1.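

In this assay, putting isopropyl in place of hydrogen on a saturated chain carbon bound to an oxygen on an aromatic ring, which turns methoxy into isobutoxy, gives a 1.3-fold lower number from compound 2 to compound 3 (0.11 log units; within the scatter), so compound 2 and compound 3 cannot be told apart. Within the data shown here, this is the first information about this position, and it shows that three extra carbon atoms can be added there without a change beyond the scatter, unlike the exchange that gave a 23-fold lower number from compound 1 to compound 2 (1.37 log units; beyond the scatter). No supporting measurement is available to explain this result.

This single pair leaves open whether an amine or a carboxylic acid on that chain carbon would also leave the number within the scatter. It also cannot show whether isobutoxy would behave the same way alongside the (morpholin-4-yl)carbonyl group of compound 1.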